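Adenosine A3 inhibition: a benzyl substituent change in the series

This account rests on a few compounds, and the source may have more. Where it says the series, first, only, none or still open, it means among the compounds named here.

Compound 1, `CCCn1c(=O)[nH]c2nc(-c3ccc(S(=O)(=O)N4CCN(c5ccc(F)cc5)CC4)cc3)[nH]c2c1=O`: 38%
Compound 2, `CCCn1c(=O)[nH]c2nc(-c3ccc(S(=O)(=O)N4CCN(Cc5cccc(Br)c5)CC4)cc3)[nH]c2c1=O`: 23%
Compound 3, `CCCn1c(=O)c2[nH]c(-c3ccc(S(=O)(=O)N4CCN(c5ccc(Cl)cc5)CC4)cc3)nc2n(C)c1=O`: 39%

Three compounds sharing one core were tested in an assay on CHO cells for displacement of a labelled ligand from adenosine receptor A3 (Homo sapiens), read by scintillation counting, with a stated time of 45 min, tested at 1 uM, in the presence of a further agent that is not named here; on this read-out lower numbers stand for less inhibition and higher numbers for more inhibition at the one concentration tested (going by the name of the read-out). Compound 2 stands lowest of the three: compound 1 lies nearest, and compound 3 furthest, both beyond the scatter. Among the measured compounds shown here, the only single-point step among them is a number 15 percentage points lower from compound 1 to compound 2 (beyond the scatter), where a 3-bromobenzyl replaces a 4-fluorophenyl on the amine nitrogen in the ring.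

Compound 4, `CCCn1c(=O)[nH]c2nc(-c3ccc(S(=O)(=O)N4CCN(Cc5ccc(Br)c(F)c5)CC4)cc3)[nH]c2c1=O`, has not been measured. It differs from compound 2 by 4-bromo-3-fluorophenyl in place of 3-bromophenyl on a saturated chain carbon bound to an amine nitrogen in a ring. For the measured compounds named here, no measured step alters the substituents of this benzyl ring, so the one known step does not bear directly on the change; the data give no basis for a shift beyond the scatter in either direction. The step from compound 2 to compound 4 in this assay is therefore expected to be small: a number 2 percentage points higher from compound 2 to compound 4 (within the scatter). For compound 4 the estimated value is 25%, with a range from 10% to 40%.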

Compound 4, a percentage reported as inhibition, at one concentration (the size of the read-out at that concentration, not a potency): 27%
Compound 4: the middle estimate sits 2 percentage points below what was measured, and the stated range covers the measured number.
By their numbers in this assay, from the lowest: compounds 2 and 4 (each within the scatter of the next); then compounds 1 and 3 (each within the scatter of the next).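

In this assay, 4-bromo-3-fluorophenyl in place of 3-bromophenyl on a saturated chain carbon bound to an amine nitrogen in a ring gives a number 4 percentage points higher from compound 2 to compound 4 (within the scatter), so this change within the benzyl ring leaves the read-out inside the scatter. Against the 4-fluorophenyl group, 4-bromo-3-fluorobenzyl gives a number 11 percentage points lower from compound 1 to compound 4 (beyond the scatter), which means the fall seen with 3-bromobenzyl now appears with a second benzyl group, though both cases rest on the single comparator compound 1. Nothing available explains either step.

Still open, from the compounds shown here alone, is how a plain benzyl group, or a benzyl ring carrying a methoxy group or a carboxylic acid, would read at this place. A single concentration also leaves the potency of all these compounds unresolved.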